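Swapping Methoxy for Chloro on the Pendant Phenyl

A few compounds are considered here, and "the series" means these few. Any claim that something is new, unique, unknown or untested is made for them only; others in the source may bear on it.

Three compounds share one core and differ only in the aryl group attached to it. Compound 1 `COc1cc2c(Oc3ccc(NC(=O)c4cc(-c5ccccc5)nc5ccccc45)cc3F)ccnc2cc1OCCCN1CCCCC1` carries an unsubstituted phenyl, compound 2 `COc1ccc(-c2cc(C(=O)Nc3ccc(Oc4ccnc5cc(OCCCN6CCCCC6)c(OC)cc45)c(F)c3)c3ccccc3n2)cc1` a 4-methoxyphenyl, and compound 3 `COc1cccc(-c2cc(C(=O)Nc3ccc(Oc4ccnc5cc(OCCCN6CCCCC6)c(OC)cc45)c(F)c3)c3ccccc3n2)c1` a 3-methoxyphenyl. In a functional assay on SMMC-7721 cells (Homo sapiens) for cytotoxicity, read by MTT assay, with a stated time of 72 h (on this read-out lower numbers stand for stronger inhibition and higher numbers for weaker inhibition), compound 1 gives 290 nM. In this assay compound 2 gives 210 nM, and compound 3 gives 380 nM. The steps among them are all small: a 1.4-fold lower number from compound 1 to compound 2 (0.14 log units; within the scatter), a 1.3-fold higher number from compound 1 to compound 3 (0.12 log units; within the scatter) and a 1.8-fold higher number from compound 2 to compound 3 (0.26 log units; within the scatter). Compound 3 therefore sits within the scatter of both of its companions.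

Compound 4 `COc1cc2c(Oc3ccc(NC(=O)c4cc(-c5cccc(Cl)c5)nc5ccccc45)cc3F)ccnc2cc1OCCCN1CCCCC1` differs from compound 3 by chloro in place of methoxy on an aromatic carbon, so that 3-methoxyphenyl becomes 3-chlorophenyl. Going by the values given here, no measured step places a chloro on this ring, so the only guidance is indirect: adding the methoxy to compound 1 or moving it between compound 2 and compound 3 never carried the number beyond the scatter. The expected step is accordingly a 1.2-fold lower number from compound 3 to compound 4 (0.07 log units; within the scatter), with no direction favoured. Compound 4 is expected to give 320 nM, within a range from 150 nM to 700 nM.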

Compound 4, half-maximal inhibitory concentration: 30 nM
Compound 4: the middle estimate sits 11-fold (1.03 log units) above what was measured; measured number below the stated range.
By their numbers in this assay, from the lowest: compound 4; then compounds 2, 1 and 3 (each within the scatter of the next).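

In this assay, going by these compounds alone, the exchange of methoxy for chloro on this ring gives a 13-fold lower number from compound 3 to compound 4 (1.10 log units; beyond the scatter) and so shows that the group at this place can move the number well beyond the scatter, which no methoxy step among the earlier compounds did. The same holds against the other two compounds: chloro in place of hydrogen gives a 9.7-fold lower number from compound 1 to compound 4 (0.99 log units; beyond the scatter) and 3-chlorophenyl in place of 4-methoxyphenyl gives a 7.0-fold lower number from compound 2 to compound 4 (0.85 log units; beyond the scatter) with both steps printed as beyond the scatter. Nothing at hand accounts for this difference between chloro and methoxy.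

The compounds shown leave open whether bromo, fluoro or methyl at this place would give a similar step. They also leave open whether chloro on another carbon of this ring would do the same.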